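This account rests on a few compounds, and the source may have more. Where it says the series, first, only, none or still open, it means among the compounds named here.

Compound 1 `CC1=CC[C@H](C(C)(C)N=C=S)CC1`: 57600 nM
Compound 2 `CC1=CC[C@H](C(C)(C)NC(=S)NN)CC1`: 900 nM
Compound 3 `COc1ccc(/C=N/NC(=S)NC(C)(C)[C@H]2CC=C(C)CC2)cc1`: 31200 nM

Going by the values given here, in a functional assay on MCF7 cells (Homo sapiens) for inhibition, read by sulforhodamine B assay, with a stated time of 48 h (a lower number here means a stronger inhibitor of growth, a higher number a weaker inhibitor of growth), compound 1 gives 57600 nM and compound 2 gives 900 nM; the one measured step between them, a 64-fold lower number from compound 1 to compound 2 (1.81 log units; beyond the scatter), is large. Compound 3 gives 31200 nM in this assay. Its number and that of compound 1 lie within the scatter of each other, while compound 2 sits far lower than compound 3. Compound 4 `CC1=CC[C@H](C(C)(C)NC(=S)N/N=C/c2ccccc2Cl)CC1` has not yet been measured. It differs from compound 3 in one place: 2-chlorophenyl in place of 4-methoxyphenyl on a carbon with a double bond to nitrogen. Among the compounds with values here, no measured pair differs in this way; the step from compound 1 to compound 2 alters the part on the saturated chain carbon and not the group on the carbon with a double bond to nitrogen, so it does not bear on this change. With nothing to lean on, no step beyond the scatter is expected, and compound 4 is estimated to give about 30000 nM in this assay, with a range from 8000 nM to 100000 nM. That estimate is expected to amount to a 1.0-fold lower number from compound 3 to compound 4 (0.02 log units; within the scatter).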

Compound 4, concentration for 50% growth inhibition: 11000 nM
Compound 4: middle estimate off by 2.7-fold (0.44 log units), on the high side; low and high end bracket the measured number.
By their numbers in this assay, from the lowest: compound 2; then compound 4; then compounds 3 and 1 (each within the scatter of the next).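

In this assay, the group on the carbon with a double bond to nitrogen proves able to shift the number: a 2.8-fold lower number from compound 3 to compound 4 (0.45 log units; beyond the scatter) accompanies 2-chlorophenyl in place of 4-methoxyphenyl, a modest step but one beyond the scatter. Going by these compounds alone, the only earlier step altered the part on the saturated chain carbon, so this is the first sign that the aromatic end of the molecule also counts in this assay. Nothing measured here accounts for the step.

The change swaps the chlorine for the methoxy group and alters the group's place on the ring at once, so the compounds shown do not separate these two changes. From the compounds shown here alone, whether an unsubstituted phenyl, a 4-chlorophenyl or a pyridine ring on this carbon would give a lower or higher number remains open.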